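The compounds below may be only part of what the source reports. "The series", "measured", "known", "first", "only" and "open" are said of these compounds alone.

Of the compounds shown here, two have been tested so far in a functional assay on L02 cells (Homo sapiens) for inhibition, read by Griess assay, with stated times of 1 h and 24 h; a lower number here means a stronger inhibitor, a higher number a weaker inhibitor. Compound 1 `COc1cc(/C=C/c2nc(N3CCCC3)c3sccc3n2)cc(OC)c1OC` gives 681000 nM in this assay, a weak result. Compound 2 `COc1cc(/C=C/c2nc(Nc3ccc(O)cc3)c3sccc3n2)cc(OC)c1OC` carries (4-hydroxyphenyl)amino in place of pyrrolidin-1-yl on an aromatic carbon. In this assay compound 2 reaches only a limit, > 1000000 nM, so no exact number is known for it. The step of an at least 1.4-fold higher number from compound 1 to compound 2 (0.16 log units; that floor lies within the scatter) therefore cannot be sized, and its floor lies within the usual scatter; this is the boundary of the measurement itself (the limit of > 1000000 nM in this assay, at which 1 of the 2 values shown sits). Compound 3 `COc1cc(/C=C/c2nc(NCc3ccc(Cl)cc3)c3sccc3n2)cc(OC)c1OC` has not yet been measured. It differs from compound 2 by 4-chlorobenzyl in place of 4-hydroxyphenyl on a nitrogen on an aromatic ring. Among the compounds with values here, the only measured step, the exchange of pyrrolidin-1-yl for (4-hydroxyphenyl)amino, is a different kind of change and gives no firm guidance on direction, and compound 2 offers a limit rather than a number to start from. The step of an at least 1.2-fold lower number from compound 2 to compound 3 (0.09 log units; that floor lies within the scatter) is therefore expected to stay small, with a real chance that compound 3 again shows only a limit. Compound 3 is estimated at 800000 nM in this assay, within a range from 200000 nM to 3000000 nM.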

Compound 3, half-maximal inhibitory concentration: > 1000000 nM
Compound 3: only a limit was reported (the forecaster's own chance of this, stated with the estimate: 55%); at least 1.2-fold (0.09 log units) between middle value and limit.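

Compound 2 and compound 3 cannot be compared in size, because both stand at the limit of the measurement: the limit of > 1000000 nM in this assay, at which 2 of the 3 values shown sit. The exchange of pyrrolidin-1-yl for (4-chlorobenzyl)amino on an aromatic carbon gives an at least 1.4-fold higher number from compound 1 to compound 3 (0.16 log units; that floor lies within the scatter), so no real difference can be claimed from that floor alone. What is new is that a second, quite different group on the nitrogen, 4-chlorobenzyl in place of 4-hydroxyphenyl, also yields no exact number, which leaves compound 1 as the only one of the three with a measured value.

Going by these compounds, how far compound 2 and compound 3 lie past the limit remains unknown, so neither the direction nor the size of this change can be stated. Also open, on these data alone, is how a small amine such as dimethylamino, or a benzyl group carrying a carboxylic acid instead of chlorine, would read in this assay, and whether any group at this place would give a clearly lower number than compound 1.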